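Exchanging the nitro group of compound 3 for a ring fluorine

The compounds below may be only part of what the source reports. "The series", "measured", "known", "first", "only" and "open" are said of these compounds alone.

Compounds measured so far:
compound 1, `CCN(CC)c1nc(Nc2cccc(C(=O)O)c2)nc(OC(C(F)(F)F)C(F)(F)F)n1`, 160 nM
compound 2, `CCN(CC)c1nc(Nc2cccc(Cl)c2)nc(OC(C(F)(F)F)C(F)(F)F)n1`, 2800 nM
compound 3, `CCN(CC)c1nc(Nc2cccc([N+](=O)[O-])c2)nc(OC(C(F)(F)F)C(F)(F)F)n1`, 200 nM

In an assay on cells for activation of Cystic fibrosis transmembrane conductance regulator (Homo sapiens), read by fluorescence, with stated times of 10 min and 12 s (on this read-out lower numbers stand for an effect already at smaller amounts and higher numbers for an effect only at larger amounts of compound), compound 3 gives 200 nM. Among the three numbers it sits second highest: its nearest neighbour is compound 1, which in this assay gives 160 nM, a gap within the scatter; furthest from it is compound 2, which gives 2800 nM.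

Compound 4, `CCN(CC)c1nc(Nc2ccc(F)cc2)nc(OC(C(F)(F)F)C(F)(F)F)n1`, has not yet been measured. The change from compound 3 is 4-fluorophenyl in place of 3-nitrophenyl on a nitrogen on an aromatic ring. Among the measured compounds shown here, the measured step that bears on it most is the one in which a group without hydrogen-bond acceptors replaced the nitro group, in reverse: a 14-fold lower number from compound 2 to compound 3 (1.15 log units; beyond the scatter). The related step of an 18-fold higher number from compound 1 to compound 2 (1.24 log units; beyond the scatter) points the same way. Both are large and beyond the scatter, whereas a 1.3-fold higher number from compound 1 to compound 3 (0.10 log units; within the scatter) stays within it. For the measured compounds named here, compound 4 also moves the substituent to another place on the phenyl ring, for which no measured pair exists.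

Compound 4 is therefore expected to show a higher number in this assay, with a step of about a 15-fold higher number from compound 3 to compound 4 (1.18 log units; beyond the scatter). The estimate for compound 4 is 3000 nM, within a range from 800 nM to 12000 nM.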

Compound 4, half-maximal effective concentration: 700 nM
For compound 4 the middle estimate is 4.3-fold (0.63 log units) above the measured one; measured number outside the range, below it.
By their numbers in this assay, from the lowest: compounds 1 and 3 (each within the scatter of the next); then compound 4; then compound 2.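

In this assay, the step of a 4.0-fold lower number from compound 2 to compound 4 (0.60 log units; beyond the scatter) shows that a ring substituent without hydrogen-bond acceptors on this nitrogen does not by itself bring the full loss seen with the 3-chlorophenyl group, so the acceptor count alone does not set the number across these compounds. Among the compounds shown here, the 3-nitrophenyl and 3-carboxyphenyl groups still give lower numbers, with a 3.5-fold higher number from compound 3 to compound 4 (0.54 log units; beyond the scatter) and a 4.4-fold higher number from compound 1 to compound 4 (0.64 log units; beyond the scatter), both modest but beyond the scatter, so this position tolerates the 4-fluorophenyl group better than the earlier compounds suggested, though not as well as those two groups. Nothing given here accounts for these differences.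

Going by these compounds, because compound 4 changes both the substituent and its place on the phenyl ring, what remains open is whether its difference from compound 2 belongs to the fluorine or to the new place, a question that a 3-fluorophenyl or a 4-chlorophenyl group on the same nitrogen would separate. Also open, on these data alone, is how a nitrile, an amide or an amine on this phenyl ring would compare with the nitro and carboxy groups.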